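Working notes: cytotoxicity of compounds 1 to 4

The source may report more compounds than this note shows. Statements on the series, on what has been measured and on what is new or still open speak of the compounds shown alone.

Measured in a functional assay on HepG2 cells (Homo sapiens) for cytotoxicity; on this read-out lower numbers stand for higher toxicity in this test and higher numbers for lower toxicity in this test:
- compound 1 `O=c1ccn(COC(CO)CO)c(=O)[nH]1` gives > 462000 nM, a limit of the test.
- compound 2 `O=c1[nH]c(=O)n(COC(CO)CO)cc1[N+](=O)[O-]` gives > 383000 nM, a limit.
- compound 3 `Cc1cn(COC(CO)CO)c(=O)[nH]c1=O` gives > 434000 nM, a limit.

Compound 1 thus stands only at a limit, as do the other two; the three limits (the limit of > 462000 nM in this assay, at which 1 of the 3 values shown sits), the limit of > 383000 nM in this assay, at which 1 of the 3 values shown sits, and the limit of > 434000 nM in this assay, at which 1 of the 3 values shown sits, each carry one value. Compound 4 `O=c1[nH]c(=O)n(COC(CO)CO)cc1CO` differs from compound 1 by hydroxymethyl in place of hydrogen on an aromatic carbon. The measured steps at this carbon are a step that the two limits leave unreadable from compound 1 to compound 2 and a step that the two limits leave unreadable from compound 1 to compound 3, and neither has a readable size. No step beyond the scatter can be expected in this assay in either direction. Compound 4 is expected to give 500000 nM (range 200000 nM to 2000000 nM), most likely again only a limit, an expected step that the limit leaves unreadable from compound 1 to compound 4.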

Compound 4, half-maximal cytotoxic concentration: > 406000 nM
Compound 4: a limit, no number (the forecaster's own chance of this, stated with the estimate: 85%); the middle value does not contradict the limit.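

Among the compounds shown here, compound 4 gives > 406000 nM, again a limit, so no step between compound 4 and compound 1, compound 2 or compound 3 can be read. The compounds shown leave open whether any substituent at this aromatic carbon gives a numerical value in this assay.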